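A few compounds are considered here, and "the series" means these few. Any claim that something is new, unique, unknown or untested is made for them only; others in the source may bear on it.

Measured compounds:
Compound 1, `CN1CCc2c(sc(NC(=O)Nc3ccc(Cl)cc3)c2C(N)=O)C1`: in a functional assay (strain AB) with Danio rerio as the target, read by microscopy, with a stated time of 1 h (on this read-out higher numbers stand for an effect only at larger amounts of compound and lower numbers for an effect already at smaller amounts), compound 1 gives 4700 nM.
Compound 2, `CCN1CCc2c(sc(NC(=O)Nc3cccc(C#N)c3)c2C(N)=O)C1`: in this assay compound 2 gives 10300 nM.

Compound 1 holds the lowest of the two numbers; its nearest neighbour, compound 2, gives a higher number, and that gap lies beyond the scatter. For the measured compounds named here, compounds 1 and 2 differ in more than one place, so no single step connects them; their two values show only that compound 1 has the lower number.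

Compound 3, `CC(C)N1CCc2c(sc(NC(=O)Nc3ccc(Cl)cc3)c2C(N)=O)C1`, remains to be measured. It differs from compound 1 as follows: isopropyl in place of methyl on an amine nitrogen in a ring. Going by the values given here, no measured pair isolates this change, so nothing in the data fixes its size or direction. The expected step is a 1.3-fold higher number from compound 1 to compound 3 (0.11 log units; within the scatter), small and likely within or only just beyond the scatter. Compound 3 is accordingly estimated at 6000 nM, with a range from 2500 nM to 15000 nM.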

Compound 3, half-maximal effective concentration: 1490 nM
Compound 3: middle estimate off by 4.0-fold (0.60 log units), on the high side; measured number outside the range, below it.
By their numbers in this assay, from the lowest: compound 3; then compound 1; then compound 2.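

In this assay the amine nitrogen in the ring now has its first single-change read, with isopropyl in place of methyl giving a 3.2-fold lower number from compound 1 to compound 3 (0.50 log units; beyond the scatter) and a step that lies beyond the scatter. This position therefore accepts the larger isopropyl without losing the effect, and here the number falls as the group grows from methyl to isopropyl. Nothing at hand bears on the reason for this step.

Two points on a single pair cannot show whether the number keeps falling with further growth at this nitrogen, so a tert-butyl, a cyclopentyl, a benzyl or a bare hydrogen there would each be informative. Going by these compounds, it also remains open whether the same change carries over when the other end of the urea differs, as it does in compound 2.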